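The source may hold more compounds than are shown below. What is called first, only, known or untested is meant among the compounds shown, and "the series" means these compounds.

Measured compounds:
compound 1 `Cc1nc(N(C)C(=O)NC(=O)c2c(F)cccc2F)sc1C(=O)N/N=C/c1ccc(Cl)cc1` — a functional assay on HepG2 cells (Homo sapiens) for inhibition, read by MTT assay, with a stated time of 72 h; on this read-out higher numbers stand for weaker inhibition and lower numbers for stronger inhibition: > 100 ug/mL, a limit of the assay
compound 2 `CN(C(=O)NC(=O)c1ccc([N+](=O)[O-])cc1)c1nc(C(F)(F)F)c(C(=O)N/N=C/c2ccc([N+](=O)[O-])cc2)s1` — this assay: 12.3 ug/mL
compound 3 `CN(C(=O)NC(=O)c1cccc(C(F)(F)F)c1)c1nc(C(F)(F)F)c(C(=O)N/N=C/c2cc(C(F)(F)F)cc(C(F)(F)F)c2)s1` — this assay: 5.38 ug/mL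

Compound 1 stands at the limit of the assay, so only a bound and no number is known for it (the limit of > 100 ug/mL in this assay, at which 1 of the 3 values shown sits). Compounds 2 and 3, which carry a different core and other substituents, give numbers. Compound 4 `Cc1nc(N(C)C(=O)NC(=O)c2c(F)cccc2F)sc1C(=O)N/N=C/c1ccccc1C(F)(F)F` keeps the core of compound 1 and differs by 2-(trifluoromethyl)phenyl in place of 4-chlorophenyl on a carbon with a double bond to nitrogen, in words: 2-(trifluoromethyl)phenyl in place of 4-chlorophenyl on a carbon with a double bond to nitrogen. Going by the values given here, no measured pair covers this change, so the set gives no direction for it. For compound 4 the expected step is a step that the limit leaves unreadable from compound 1 to compound 4, none beyond the scatter. The estimate for compound 4 in this assay is 120 ug/mL, expected between 40 ug/mL and 300 ug/mL.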

Compound 4, half-maximal inhibitory concentration: 1.11 ug/mL
The estimate for compound 4 lay 110-fold (2.03 log units) above the measured number, and the stated range ends above it.
By their numbers in this assay, from the lowest: compound 4; then compound 3; then compound 2. At a limit, above all of these: compound 1.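

In this assay, going by these compounds alone, the group on a carbon with a double bond to nitrogen gives the first single-place change: 2-(trifluoromethyl)phenyl in place of 4-chlorophenyl gives an at least 90-fold lower number from compound 1 to compound 4 (1.95 log units; beyond the scatter). With this group, compound 4 gives 1.11 ug/mL, so the core of compound 1 is not tied to weak inhibition. Compound 1 stands at a limit, so this step is a bound and its full size stays unknown: the limit of > 100 ug/mL in this assay, at which 1 of the 4 values shown sits.

The change alters both the substituent and its ring location, and the compounds shown do not separate the two. An unsubstituted phenyl group at this place would give a common reference for both substituents.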